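Swapping the chlorophenyl group for a hydroxyphenyl group

The compounds below may be only part of what the source reports. "The series", "measured", "known", "first", "only" and "open" are said of these compounds alone.

Compound 1, `COc1cc(NC(C)CCCNC(=O)Nc2cccc(Cl)c2)c2ncccc2c1`: 22000 nM
Compound 2, `COc1cc(NC(C)CCCNC(=O)Nc2ccc(F)cc2)c2ncccc2c1`: 26000 nM

Both numbers come from a functional assay on CCRF-CEM cells (Homo sapiens) for inhibition, read by MTT assay, with a stated time of 72 h; a lower number here means a stronger inhibitor, a higher number a weaker inhibitor. Compound 1 holds the lower of the two, but the gap to compound 2 is within the scatter. Compound 3, `COc1cc(NC(C)CCCNC(=O)Nc2ccc(O)cc2)c2ncccc2c1`, differs from compound 1 by 4-hydroxyphenyl in place of 3-chlorophenyl on an amide-type nitrogen. Among the measured compounds shown here, the only measured step that touches the same place is a 1.2-fold higher number from compound 1 to compound 2 (0.07 log units; within the scatter), which shows a replacement there barely moving the number. Compound 3 is therefore expected to give 30000 nM, with a plausible range of 12000 nM to 80000 nM. This estimate means a step of a 1.4-fold higher number from compound 1 to compound 3 (0.13 log units; within the scatter), expected to stay near the scatter.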

Compound 3, half-maximal inhibitory concentration: 23000 nM
Beside the measured number, compound 3's estimate is 1.3-fold (0.12 log units) above it, within the range that was stated.
By their numbers in this assay, from the lowest: compounds 1, 3 and 2 (each within the scatter of the next).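

Placing 4-hydroxyphenyl on the amide-type nitrogen gives a 1.0-fold higher number from compound 1 to compound 3 (0.02 log units; within the scatter) in this assay, and replacing fluoro with hydroxy on the aromatic carbon gives a 1.1-fold lower number from compound 2 to compound 3 (0.05 log units; within the scatter). So a phenyl group carrying a hydrogen-bond donor and acceptor reads the same, within the scatter, as the two halogen-bearing phenyl groups, which carry neither. No measurement here offers an explanation for this. Still open, on these data alone, is whether an amine or a carboxylic acid on that phenyl ring, or a plain alkyl chain replacing the ring, would give a number beyond the scatter.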